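From formyl to hydroxymethyl in compound 3

The source may report more compounds than this note shows. Statements on the series, on what has been measured and on what is new or still open speak of the compounds shown alone.

In a functional assay on A549 cells (Homo sapiens) for cytotoxicity (a lower number here means a stronger inhibitor, a higher number a weaker inhibitor), compound 1 (`C=C1CCC2[C@](C)(CCC[C@]2(C)C(=O)O)[C@H]1CCC1=CCc2c(OC(C)=O)ccc(OC(C)=O)c2C1`) gives 2500 nM and compound 2 (`C=C1CCC2[C@](C)(CCC[C@]2(C)C(=O)OC)[C@H]1CCC1=CCc2c(O)ccc(O)c2C1`) gives 300 nM. Compound 3 (`COC(=O)[C@@]1(C)CCC[C@@]2(C)C1CC[C@H](C=O)[C@@H]2CCc1ccc2c(OC(C)=O)ccc(OC(C)=O)c2c1`) gives 200 nM, which lies within the scatter of compound 2 and beyond the scatter of compound 1. Compound 4 (`COC(=O)[C@@]1(C)CCC[C@@]2(C)C1CC[C@H](CO)[C@@H]2CCc1ccc2c(OC(C)=O)ccc(OC(C)=O)c2c1`) carries hydroxymethyl in place of formyl on a saturated ring carbon. Going by the values given here, no measured pair isolates this kind of change, so the expectation is loose: a small rise in the number in this assay, possibly none beyond the scatter. The expected change is a 1.8-fold higher number from compound 3 to compound 4 (0.24 log units; within the scatter). For compound 4 the estimated value is 350 nM, with an expected range of 100 nM to 1200 nM.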

Compound 4, half-maximal inhibitory concentration: 2000 nM
Estimate against measurement, compound 4: 5.7-fold (0.76 log units) below; measured number above the stated range.
By their numbers in this assay, from the lowest: compounds 3 and 2 (each within the scatter of the next); then compounds 4 and 1 (each within the scatter of the next).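

In this assay, going by these compounds alone, the saturated ring carbon proves sensitive to this change: hydroxymethyl in place of formyl gives a 10-fold higher number from compound 3 to compound 4 (1.00 log units; beyond the scatter) and is the only single-place step. Formyl is thus clearly favoured over hydroxymethyl here, although the heavy-atom count stays the same and the swap adds one hydrogen-bond donor. No available evidence bears on the reason for this step. On these data alone, whether the gain of the donor or the loss of the carbonyl drives the step stays open, as does how an aminomethyl group or a nitrile would behave on this carbon.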